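Changing the Aryl Group on a Triazole-Bearing Butenolide

The source may report more compounds than this note shows. Statements on the series, on what has been measured and on what is new or still open speak of the compounds shown alone.

Compound 1 `O=C1O/C(=C\Cn2cc(-c3ccc(Br)cc3)nn2)C(OCc2ccccc2)=C1OCc1ccccc1` was tested in a functional assay on MCF7 cells (Homo sapiens) for antiproliferative activity, read by MTT assay, with a stated time of 72 h; on this read-out lower numbers stand for stronger inhibition and higher numbers for weaker inhibition. In this assay compound 1 gives only a limit, > 100000 nM, and therefore no number of its own; it sits at the limit of > 100000 nM in this assay, at which 1 of the 2 values shown sits. For the measured compounds named here, compound 2 `CCCCc1cn(C[C@H](O)[C@H]2OC(=O)C(OCc3ccccc3)=C2OCc2ccccc2)nn1`, which bears a butyl group and a hydroxyl-containing saturated linker in place of the double bond, gives 7910 nM in this assay; the two values show that compound 2 reaches a measurable number while compound 1 does not, but no single change connects them, so no step can be drawn. Compound 3 `COc1ccccc1-c1cn(C/C=C2\OC(=O)C(OCc3ccccc3)=C2OCc2ccccc2)nn1` differs from compound 1 in one place: 2-methoxyphenyl in place of 4-bromophenyl on an aromatic carbon. Going by the values given here, no measured step covers this change, and nothing among the measured compounds shows that swapping one aryl group for another changes the outcome. Compound 3 is therefore expected to remain near the limit, at about 80000 nM, within a range of 15000 nM to 400000 nM. The expected step of an at least 1.2-fold lower number from compound 1 to compound 3 (0.09 log units; that floor lies within the scatter) would amount to none beyond the usual scatter, with a real chance that only a limit is reported again.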

Compound 3, half-maximal inhibitory concentration: > 100000 nM
Compound 3: only a limit was reported; the forecaster's own chance of this, stated with the estimate: 60%; middle value at least 1.2-fold (0.09 log units) from the limit.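

In this assay compound 3 gives only a limit, > 100000 nM. For the compounds shown here, compound 1 also gives only a limit, so no step between compound 1 and compound 3 can be read, and the effect of 2-methoxyphenyl in place of 4-bromophenyl stays unknown: the limit of > 100000 nM in this assay, at which 2 of the 3 values shown sit. The compounds shown leave open whether any aryl group on this shared core would give a measurable number.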